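The compounds below may be only part of what the source reports. "The series", "measured", "known", "first", "only" and "open" are said of these compounds alone.

Measured compounds in a functional assay on IMR-32 cells (Homo sapiens) for antiproliferative activity, read by sulforhodamine B assay, with a stated time of 48 h; on this read-out higher numbers stand for weaker inhibition of growth and lower numbers for stronger inhibition of growth:
- compound 1 `O=C1COc2ccccc2N1CCCn1cc(-c2ccccc2)nn1`: 370 nM
- compound 2 `COc1ccc(-c2cn(CCCN3C(=O)COc4ccccc43)nn2)cc1`: 49900 nM
- compound 3 `CCCCc1cn(CCCN2C(=O)COc3ccccc32)nn1`: 5700 nM

Compound 2 stands at the highest number of the three. Its nearest neighbour is compound 3, with an 8.8-fold lower number from compound 2 to compound 3 (0.94 log units; beyond the scatter); the furthest is compound 1, with a 130-fold higher number from compound 1 to compound 2 (2.13 log units; beyond the scatter). Compound 1 to compound 3 shows a 15-fold higher number from compound 1 to compound 3 (1.19 log units; beyond the scatter).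

Compound 4 `O=C1COc2ccccc2N1CCCn1cc(CCCCl)nn1` is not yet measured. Its difference from compound 2 is 3-chloropropyl in place of 4-methoxyphenyl on an aromatic carbon. Within the data shown here, the step that bears most directly on this is the one from compound 2 to compound 3, where a group with no ring entered in place of 4-methoxyphenyl and the number fell by a modest amount, an 8.8-fold lower number from compound 2 to compound 3 (0.94 log units; beyond the scatter). Compound 4 also carries a group with no ring on the same aromatic carbon, so a step of similar size and in the same direction is expected, landing near compound 3 rather than near compound 1. The step from compound 1 to compound 3, a 15-fold higher number from compound 1 to compound 3 (1.19 log units; beyond the scatter), cautions that a chain on this position does not reach the number of compound 1.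

The expected step is an 8.3-fold lower number from compound 2 to compound 4 (0.92 log units; beyond the scatter), a lower number in this assay. Compound 4 is therefore estimated at 6000 nM, with a range from 2000 nM to 20000 nM.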

Compound 4, concentration for 50% growth inhibition: 200 nM
Estimate against measurement, compound 4: 30-fold (1.48 log units) above; the whole stated range lies above it.
By their numbers in this assay, from the lowest: compounds 4 and 1 (each within the scatter of the next); then compound 3; then compound 2.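

In this assay, this aromatic carbon of the five-membered ring does not need a ring-bearing group to reach the level of compound 1: with 3-chloropropyl in place of phenyl, the two compounds cannot be separated (a 1.9-fold lower number from compound 1 to compound 4 (0.27 log units; within the scatter)), a step within the scatter. The chain itself also counts, since chains with no ring do not all stay close to compound 3; chloro in place of methyl, three bonds along the chain from the aromatic carbon, gives a large step (a 29-fold lower number from compound 3 to compound 4 (1.45 log units; beyond the scatter)). Loss of 4-methoxyphenyl therefore has no fixed outcome at this position: 3-chloropropyl gives a much larger step (a 250-fold lower number from compound 2 to compound 4 (2.40 log units; beyond the scatter)) than butyl does (an 8.8-fold lower number from compound 2 to compound 3 (0.94 log units; beyond the scatter)).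

From the compounds shown here alone, it remains open whether chloro is particular at the end of the chain, or whether a hydroxyl, an amine or a longer chain ending in chloro at this position would match compound 4. No measurement at hand accounts for the size of these steps.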